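A few compounds are considered here, and "the series" means these few. Any claim that something is new, unique, unknown or untested is made for them only; others in the source may bear on it.

Measured in a functional assay on HT-29 cells (Homo sapiens) for antiproliferative activity, read by sulforhodamine B assay, with a stated time of 48 h; a lower number here means a stronger inhibitor, a higher number a weaker inhibitor:
- compound 1 `Cc1ccc(OS(=O)(=O)c2ccc(N3CCN(C)C3=O)cc2)c(C)c1` gives 3000 nM
- compound 2 `Cc1cccc(OS(=O)(=O)c2ccc(N3CCN(C)C3=O)cc2)c1` gives 4300 nM
- compound 3 `COc1cccc(OS(=O)(=O)c2ccc(N3CCN(C)C3=O)cc2)c1` gives 2500 nM

In this assay compound 3, at 2500 nM, sits within the usual scatter of both compound 1 and compound 2, so these numbers give the three compounds no firm order.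

Compound 4 `CCN1CCN(c2ccc(S(=O)(=O)Oc3cccc(OC)c3)cc2)C1=O` differs from compound 3 in one place: methyl in place of hydrogen on a saturated chain carbon bound to an amide-type nitrogen in a ring. This is methyl in place of hydrogen on a saturated chain carbon bound to an amide-type nitrogen in a ring, which turns methyl into ethyl.

Among the measured compounds shown here, no measured pair makes this change. The three available steps, a 1.4-fold higher number from compound 1 to compound 2 (0.16 log units; within the scatter), a 1.2-fold lower number from compound 1 to compound 3 (0.08 log units; within the scatter) and a 1.7-fold lower number from compound 2 to compound 3 (0.24 log units; within the scatter), all alter the aromatic group on an oxygen and leave the 3-methyl-2-oxoimidazolidin-1-yl group untouched. They show only that this series has stayed within the scatter so far, and they give no direction for the new change. The best guide is therefore the value of compound 3 itself, and no shift beyond the scatter is expected. The expected step is no change at the digits printed from compound 3 to compound 4 (within the scatter) in this assay, with the direction left open.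

The estimate for compound 4 is 2500 nM, with an expected range from 1000 nM to 6000 nM.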

Compound 4, half-maximal inhibitory concentration: 22000 nM
The estimate for compound 4 lay 8.8-fold (0.94 log units) below the measured number, and the stated range ends below it.
By their numbers in this assay, from the lowest: compounds 3, 1 and 2 (each within the scatter of the next); then compound 4.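

Across this assay, the earlier compounds differed only in the aromatic group on an oxygen and stayed within the scatter of one another, so they said nothing about the 3-methyl-2-oxoimidazolidin-1-yl group. Turning methyl into ethyl on that group gives an 8.8-fold higher number from compound 3 to compound 4 (0.94 log units; beyond the scatter), a step beyond the scatter and the only one of that kind among the compounds shown, so this position is sensitive to the addition of a single carbon, and here that addition weakens the compound. No measurement at hand accounts for this loss of activity.

The compounds shown leave open how the number moves along this chain: whether a longer chain such as propyl weakens the compound further, and whether an amine or a hydroxyl group at the end of the chain would behave as ethyl does. From the compounds shown here alone, it is also open whether ethyl in place of methyl brings a similar step when the aromatic group on the oxygen is the 2,4-dimethylphenyl of compound 1 or the 3-methylphenyl of compound 2, rather than the 3-methoxyphenyl of compound 3.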